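Methoxy for Methylamino on a Furan-Bearing Nucleoside

A few compounds are considered here, and "the series" means these few. Any claim that something is new, unique, unknown or untested is made for them only; others in the source may bear on it.

Measured compounds:
compound 1, `COc1nc(N)nc2c1c(-c1ccco1)cn2[C@@H]1O[C@H](CO)[C@@H](O)[C@H]1O`: > 20000 nM
compound 2, `COc1ncnc2c1c(-c1cc3ccccc3o1)cn2[C@@H]1O[C@H](CO)[C@@H](O)[C@H]1O`: 13100 nM
compound 3, `CNc1ncnc2c1c(-c1ccco1)cn2[C@@H]1O[C@H](CO)[C@@H](O)[C@H]1O`: 15100 nM

All three were tested in a functional assay on K562 cells (Homo sapiens), read by MTT assay, with a stated time of 72 h; a higher number here means a weaker inhibitor, a lower number a stronger inhibitor. Compound 1 reaches only the limit of > 20000 nM, a boundary of the method rather than a number (the limit of > 20000 nM in this assay, at which 1 of the 3 values shown sits). Between the two numbers that remain, compound 3 carries the higher one, but its gap to compound 2 lies within the scatter, so no order between them can be claimed.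

Compound 4, `COc1ncnc2c1c(-c1ccco1)cn2[C@@H]1O[C@H](CO)[C@@H](O)[C@H]1O`, is not yet measured. It differs from compound 3 by methoxy in place of methylamino on an aromatic carbon. Among the measured compounds shown here, no measured pair shows this exchange, so the expectation for this assay is a step of no size beyond the scatter, in either direction. Compound 4 is therefore estimated at 12000 nM, with a range from 4000 nM to 30000 nM, a step of a 1.3-fold lower number from compound 3 to compound 4 (0.10 log units; within the scatter).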

Compound 4, half-maximal inhibitory concentration: 380 nM
For compound 4 the middle estimate is 32-fold (1.50 log units) above the measured one; measured number outside the range, below it.
By their numbers in this assay, from the lowest: compound 4; then compounds 2 and 3 (each within the scatter of the next). At a limit, above all of these: compound 1.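

With the furan-2-yl group kept, methoxy in place of methylamino on this aromatic carbon gives a 40-fold lower number from compound 3 to compound 4 (1.60 log units; beyond the scatter) in this assay, so this one exchange separates a weak compound from a far stronger one. Methoxy alone does not account for this, since compound 2 carries it too, and furan-2-yl in place of 1-benzofuran-2-yl gives a 34-fold lower number from compound 2 to compound 4 (1.54 log units; beyond the scatter). Hydrogen in place of amino gives an at least 52-fold lower number from compound 1 to compound 4 (1.72 log units; beyond the scatter), a step read from a limit and not from a number: the limit of > 20000 nM in this assay, at which 1 of the 4 values shown sits.

The compounds shown leave open why the exchange has so large an effect. They also leave open whether ethoxy or dimethylamino on this carbon would follow methoxy or methylamino.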